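This account rests on a few compounds, and the source may have more. Where it says the series, first, only, none or still open, it means among the compounds named here.

Working notes on the series. Two compounds carry a measured number. Compound 1 `O=C(O)c1ccc(N(C(=O)CCCCCBr)c2cccc(C(=O)O)c2)cc1` gives 5% in an assay on isolated protein for binding affinity to L-selectin (Homo sapiens), read by ELISA, tested at 500 uM (on this read-out higher numbers stand for more inhibition at the one concentration tested (going by the name of the read-out) and lower numbers for less inhibition), the lower of the two values. The nearest neighbour is compound 2 `CCCCCCCCCCOc1cccc(OCCCCCC(=O)N(Cc2ccc(C(=O)OC)cc2)c2cccc(C(=O)OC)c2)c1`, which in this assay gives 86%; the gap to compound 1 lies beyond the scatter, but the two structures differ in several places at once, so no single change can be read from it. Compound 3 `O=C(O)c1ccc(N(C(=O)CCCCCBr)c2ccc(C(=O)O)cc2)cc1` has the same atoms as compound 1, joined differently: 4-carboxyphenyl in place of 3-carboxyphenyl on an amide-type nitrogen. Within the data shown here, no pair of measured compounds isolates this kind of change. With compound 1 as the only anchor at 5%, the expected step for moving one carboxyphenyl isomer to the other on the amide-type nitrogen is a number 5 percentage points higher from compound 1 to compound 3 (within the scatter), a change within the scatter. For compound 3 the estimated value in this assay is 10%, with a range from 0% to 30%.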

Compound 3, a percentage reported as inhibition, at one concentration (the size of the read-out at that concentration, not a potency): 6%
Estimate against measurement, compound 3: 4 percentage points above; the measured number falls inside the stated range.
By their numbers in this assay, from the lowest: compounds 1 and 3 (each within the scatter of the next); then compound 2.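

In this assay the series now has its first step in a single place: 4-carboxyphenyl in place of 3-carboxyphenyl on an amide-type nitrogen gives a number 1 percentage points higher from compound 1 to compound 3 (within the scatter). With the rest of compound 1 held fixed, the two carboxyphenyl isomers at this position therefore cannot be told apart at the one concentration tested. No independent measurement bears on this result, so the step stands as a bare observation.

Still open, from the compounds shown here alone, is whether the number in this assay would be higher, lower or level with other groups at this position, such as an amine or a sulfonic acid in place of the carboxylic acid on the ring. The large gap to compound 2 also remains unassigned, as that compound differs from compound 1 and compound 3 in several places at once.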